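Dropping the linker: cyclobutyl directly on the ring nitrogen

This account rests on a few compounds, and the source may have more. Where it says the series, first, only, none or still open, it means among the compounds named here.

Measured so far:
compound 1 `c1nc(NC2CC2)c2ncn(CC3CC3)c2n1` gives 4 mg/kg in a functional assay on the whole organism for antagonist activity, with Rattus norvegicus as the target; a higher number here means that more compound is needed for the effect, a lower number that less compound is needed;
compound 2 `c1nc(NC2CC2)c2ncn(CC3CCC3)c2n1` gives 10 mg/kg in this assay;
compound 3 `CC(C1CC1)n1cnc2c(NC3CC3)ncnc21` gives 2 mg/kg; 4.5 mg/kg; 12.5 mg/kg (3 entries) in this assay.

Compound 2 carries the highest of the two single numbers in this assay; its nearest neighbour is compound 1, which sits a step lower, a 2.5-fold higher number from compound 1 to compound 2 (0.40 log units; beyond the scatter). Compound 3 has several entries rather than one number, and these entries, (the several entries of compound 3 in this assay, 2 mg/kg; 4.5 mg/kg; 12.5 mg/kg (3 entries)), show how widely repeated measurements of one compound can spread.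

Compound 4 `c1nc(NC2CC2)c2ncn(C3CCC3)c2n1` has not yet been measured. It differs from compound 2 by cyclobutyl in place of cyclobutylmethyl on an aromatic nitrogen: the one-carbon linker between the ring nitrogen and the four-membered ring is removed. Among the compounds with values here, none of the measured steps covers this change; the only measured step, from compound 1 to compound 2, swaps one small ring for another on a chain carbon and leaves the linker in place. Compound 2 is therefore the best anchor, and the expectation for compound 4 is a number close to it, with an estimated step of a 1.3-fold lower number from compound 2 to compound 4 (0.10 log units; within the scatter) that stays within the scatter. Compound 4 is expected to give about 8 mg/kg in this assay, with a range from 3 mg/kg to 25 mg/kg.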

Compound 4, dose for half-maximal effect: 19 mg/kg
For compound 4 the middle estimate is 2.4-fold (0.38 log units) below the measured one, within the range that was stated.
By their numbers in this assay, from the lowest: compound 1; then compounds 2 and 4 (each within the scatter of the next).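

Taking out the one-carbon linker gives, in this assay, a 1.9-fold higher number from compound 2 to compound 4 (0.28 log units; within the scatter), so with the four-membered ring on the aromatic nitrogen, this linker can go without a change that clears the scatter. The wider swap, cyclobutyl in place of cyclopropylmethyl, does clear it, with a 4.8-fold higher number from compound 1 to compound 4 (0.68 log units; beyond the scatter), which shows that this position responds to its group, though only modestly so far. Even that reading needs care, since repeated entries for a single compound can spread widely: the several entries of compound 3 in this assay, 2 mg/kg; 4.5 mg/kg; 12.5 mg/kg (3 entries)

Going by these compounds, it remains open whether a cyclopropyl or a cyclopentyl ring set directly on the ring nitrogen would follow cyclobutyl. The compounds shown also cannot tell how an open chain such as isopropyl, or a longer linker such as cyclobutylethyl, would behave at this position.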